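The source may hold more compounds than are shown below. What is called first, only, known or untested is meant among the compounds shown, and "the series" means these compounds.

Three compounds of this set share one core, and a fourth is considered here without a result so far. Compound 1 has the structure `Cc1c(OCCCCOc2ccc(C(=O)O)cc2)ccc(C(=O)CC2CCCC2)c1O`. In an assay on HEK293 cells for positive allosteric modulation of metabotropic glutamate receptor 3 (Rattus norvegicus), read by thallium flux, with a stated time of 2.5 min (on this read-out higher numbers stand for an effect only at larger amounts of compound and lower numbers for an effect already at smaller amounts), compound 1 gives only a limit, > 10000 nM, and not a number. That is the limit of > 10000 nM in this assay, at which 1 of the 3 values shown sits. Compound 2, with the structure `Cc1c(OCCCCOc2ccc(C(=O)O)cc2)ccc(C(=O)CC2CCCC2)c1C`, has been run in this assay with the entry "not determined" (no result reported), so no number is known for it. Compound 3, with the structure `Cc1c(OCCCCOc2ccc(C(=O)O)cc2)ccc(C(=O)CC(C)C)c1C`, likewise shows "not determined" (no result reported) in this assay. Compound 2 therefore stands without a single number of its own; beside it, one further value is a limit and one further entry holds no number either.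

Compound 4 has the structure `Cc1c(OCCCCOc2ccc(C(=O)O)c(Cl)c2)ccc(C(=O)CC2CCCC2)c1C` and still waits for measurement in this assay. It differs from compound 2 in one place: chloro in place of hydrogen on an aromatic carbon. No measured step between any two compounds of this set exists, so the size of the step from compound 2 to compound 4 cannot be read from anything shown, and no direction beyond the scatter is expected for it. Compound 4 is therefore estimated to give about 8000 nM in this assay, within a range from 1500 nM to 30000 nM.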

Compound 4, half-maximal effective concentration: > 10000 nM
Compound 4 was reported as a limit (the forecaster's own chance of this, stated with the estimate: 60%); at least 1.2-fold (0.09 log units) between middle value and limit.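

In this assay compound 4 gives > 10000 nM, which is a limit and not a number. Among these compounds, compound 2 has no number of its own, so no step from compound 2 to compound 4 can be read. The compounds shown leave open what chloro in place of hydrogen does here, and what number lies behind this limit: the limit of > 10000 nM in this assay, at which 2 of the 4 values shown sit.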